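This account rests on a few compounds, and the source may have more. Where it says the series, first, only, none or still open, it means among the compounds named here.

Working notes on a series of three-aryl compounds tested in a functional assay on T47D cells (Homo sapiens) for inhibition; a lower number here means a stronger inhibitor, a higher number a weaker inhibitor. Compound 1 `Oc1ccccc1-c1cc(-c2ccccc2F)cc(-c2ccccc2O)n1` gives a limit of this assay, > 50000 nM, and not a number (the limit of > 50000 nM in this assay, at which 1 of the 3 values shown sits). Compound 2 `Oc1cccc(-c2cc(-c3ccccc3F)cc(-c3ccccc3O)n2)c1` gives 24200 nM in this assay; it differs from compound 1 by 3-hydroxyphenyl in place of 2-hydroxyphenyl on an aromatic carbon, and the step is an at least 2.0-fold lower number from compound 1 to compound 2 (0.31 log units; beyond the scatter). Compound 3 `Oc1ccccc1-c1cc(-c2ccccc2C(F)(F)F)cc(-c2ccccc2O)n1` gives 22500 nM in this assay, a step of an at least 2.2-fold lower number from compound 1 to compound 3 (0.34 log units; beyond the scatter). The values of compound 2 and compound 3 lie within the scatter of each other.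

Compound 4 `Oc1cccc(-c2cc(-c3ccccc3C(F)(F)F)cc(-c3ccccc3O)n2)c1` is not yet measured. It differs from compound 3 by 3-hydroxyphenyl in place of 2-hydroxyphenyl on an aromatic carbon. This is the same kind of change as from compound 1 to compound 2, with a different surrounding: there the place was meta to a 2-fluorophenyl group, here it is meta to a 2-(trifluoromethyl)phenyl group. The two cores differ by trifluoromethyl in place of fluoro on an aromatic carbon. The earlier step, with compound 1 at a limit, is known as a minimum; its full size is not known. The expected step is a 2.0-fold lower number from compound 3 to compound 4 (0.31 log units; beyond the scatter), resting on the step of an at least 2.0-fold lower number from compound 1 to compound 2 (0.31 log units; beyond the scatter) from compound 1 to compound 2. Compound 4 is estimated at 11000 nM in this assay. The range for compound 4 is estimated from 4500 nM to 30000 nM.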

Compound 4, half-maximal inhibitory concentration: 5680 nM
Estimate against measurement, compound 4: 1.9-fold (0.29 log units) above; measured number inside the range.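

In this assay, 3-hydroxyphenyl in place of 2-hydroxyphenyl gives a 4.0-fold lower number from compound 3 to compound 4 (0.60 log units; beyond the scatter), and trifluoromethyl in place of fluoro gives a 4.3-fold lower number from compound 2 to compound 4 (0.63 log units; beyond the scatter), so each change lowers the number on both cores shown, and no compound here goes against that direction. Whether the size of the first change carries from one core to the other stays unsettled: the same change on two cores in this assay, an at least 2.0-fold lower number (0.31 log units; beyond the scatter) from compound 1 to compound 2 and a 4.0-fold lower number (0.60 log units; beyond the scatter) from compound 3 to compound 4; the limit leaves it open whether they differ The same holds for the second change, so the series supports a shared direction but neither an equal nor a larger step on the second core: the same change on two cores in this assay, an at least 2.2-fold lower number (0.34 log units; beyond the scatter) from compound 1 to compound 3 and a 4.3-fold lower number (0.63 log units; beyond the scatter) from compound 2 to compound 4; the limit leaves it open whether they differ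

The compounds shown leave open whether 3-hydroxyphenyl in place of the remaining 2-hydroxyphenyl group would lower the number further on the core of compound 4. They also leave open how an amine or a carboxylic acid in place of the hydroxyl would read in this assay, and whether either change holds on a core carrying a chloro or methoxy group instead of fluoro or trifluoromethyl.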